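A swap on the nitrogen, at the assay limit

The compounds below may be only part of what the source reports. "The series", "measured", "known", "first", "only" and "open" are said of these compounds alone.

Compound 1 `Cc1ccccc1Nc1nc(Nc2ccccc2)ncc1Cl`: > 100000 nM
Compound 2 `Cc1ccccc1Nc1nc(NCc2ccco2)ncc1Cl`: > 100000 nM

In a functional assay on Jurkat cells (Homo sapiens) for inhibition, read by CCK-8 assay, with a stated time of 48 h (a higher number here means a weaker inhibitor of growth, a lower number a stronger inhibitor of growth), compound 2 gives > 100000 nM, which is a limit of the assay and not a number. Compound 1 gives > 100000 nM, and this too is only a limit. The evidence so far therefore comes down to the limit of > 100000 nM in this assay, at which 2 of the 2 values shown sit.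

The next compound is compound 3 `Cc1ccccc1Nc1nc(Nc2ccccn2)ncc1Cl`, and it differs from compound 2 in one group: pyridin-2-yl in place of (furan-2-yl)methyl on a nitrogen on an aromatic ring. Put simply, pyridin-2-yl takes the place of (furan-2-yl)methyl on a nitrogen on an aromatic ring.

Going by the values given here, only one measured step bears on this change: a step that the two limits leave unreadable from compound 1 to compound 2. It alters the same place, but it offers neither a size nor a direction to carry over. No step beyond the usual scatter can therefore be expected in this assay on this evidence, and a further limit is the likeliest result. The expected change is a number no higher from compound 2 to compound 3 (the limit leaves the size open). For compound 3 the estimated value is 100000 nM, with an expected range of 30000 nM to 200000 nM.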

Compound 3, concentration for 50% growth inhibition: 20100 nM
For compound 3 the middle estimate is 5.0-fold (0.70 log units) above the measured one; measured number below the stated range.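

In this assay, compound 3 at 20100 nM shows that a change at this nitrogen can bring a readable effect on growth, which the two earlier compounds could not show: pyridin-2-yl in place of (furan-2-yl)methyl gives an at least 4.9-fold lower number from compound 2 to compound 3 (0.69 log units; beyond the scatter), and pyridin-2-yl in place of phenyl gives an at least 4.9-fold lower number from compound 1 to compound 3 (0.69 log units; beyond the scatter). The second step matters most for the ring itself, since a six-membered aromatic ring stands on the nitrogen at both ends of that step, yet only the pyridin-2-yl compound gives a number. Both sizes are only minimum sizes, as the starting point of each step is a limit and not a number: the limit of > 100000 nM in this assay, at which 2 of the 3 values shown sit.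

The compounds shown leave open whether the place of the ring nitrogen matters, which pyridin-3-yl or pyridin-4-yl on the same nitrogen would test, and whether a second ring nitrogen, as in pyrimidin-2-yl, would lower the number further. They also leave open how (pyridin-2-yl)methyl would compare, a group that would separate the effect of the ring from that of the extra carbon in the (furan-2-yl)methyl chain.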